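A few compounds are considered here, and "the series" means these few. Any claim that something is new, unique, unknown or untested is made for them only; others in the source may bear on it.

Measured so far: compound 1 `CCCCCCCC(=O)Nc1ccc2[nH]cc(C3CCN(C)CC3)c2n1` gives 110 nM in an assay for binding affinity to 5-hydroxytryptamine receptor 1D (Homo sapiens), read by radioligand binding; on this read-out lower numbers stand for stronger inhibition and higher numbers for weaker inhibition; compound 2 `CN1CCC(c2c[nH]c3ccc(NC(=O)C4CC4)nc23)CC1` gives 1800 nM.

Among the measured compounds shown here, compound 2 stands highest of the two numbers in this assay; its nearest neighbour is compound 1, and the single measured step, a 16-fold higher number from compound 1 to compound 2 (1.21 log units; beyond the scatter), is large. Compound 3 `CN1CCC(c2c[nH]c3ccc(NC(=O)c4cccc(F)c4)nc23)CC1` carries 3-fluorophenyl in place of cyclopropyl on a carbonyl carbon. The group on the carbonyl carbon has been varied once, and that change moved the number far; 3-fluorophenyl is neither of the two groups measured, so the expectation rests on that one step alone. Compound 3 is expected at 300 nM, range 80 nM to 1200 nM. The expected step is a 6.0-fold lower number from compound 2 to compound 3 (0.78 log units; beyond the scatter).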

Compound 3, inhibition constant: 690 nM
Compound 3: the middle estimate sits 2.3-fold (0.36 log units) below what was measured; the measured number falls inside the stated range.
By their numbers in this assay, from the lowest: compound 1; then compound 3; then compound 2.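

Going to 3-fluorophenyl on the carbonyl carbon gives a 2.6-fold lower number from compound 2 to compound 3 (0.42 log units; beyond the scatter) in this assay, so a larger group than cyclopropyl can lower the number at this position without an alkyl chain. That recovery is only partial: replacing heptyl with 3-fluorophenyl still gives a 6.3-fold higher number from compound 1 to compound 3 (0.80 log units; beyond the scatter), leaving compound 1 with the lowest number of the three. Nothing available accounts for this order.

From the compounds shown here alone, whether plain phenyl would match 3-fluorophenyl remains open, so the share of the fluorine in this step cannot be separated. Going by these compounds, it is also open whether a butyl chain would fall between cyclopropyl and heptyl.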